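A few compounds are considered here, and "the series" means these few. Any claim that something is new, unique, unknown or untested is made for them only; others in the source may bear on it.

- compound 1 `COc1cc(/C=C2\CNC/C(=C\c3cc(OC)c(OC)c(OC)c3)C2=O)cc(OC)c1OC` gives 1200 nM
- compound 2 `CCCN1C/C(=C\c2ccc(OC)c(OC)c2)C(=O)/C(=C/c2ccc(OC)c(OC)c2)C1` gives 4200 nM

In a functional assay on A549 cells (Homo sapiens) for cytotoxicity, read by MTT assay, with a stated time of 72 h (a higher number here means a weaker inhibitor, a lower number a stronger inhibitor), compound 1 gives 1200 nM and has the lower number of the two measured compounds. Compound 2 gives 4200 nM and lies above compound 1 by more than the usual scatter of repeated measurements. These two compounds differ in more than one place, so their gap does not isolate any single change.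

Compound 3 `CCN1C/C(=C\c2cc(OC)c(OC)c(OC)c2)C(=O)/C(=C/c2cc(OC)c(OC)c(OC)c2)C1` departs from compound 1 in one place only, with ethyl in place of hydrogen on an amine nitrogen in a ring. Within the data shown here, no measured pair shows this change alone. Compound 2, which also carries a chain on that nitrogen, gives 4200 nM as its reading, and this offers only a loose hint that the number may rise. A small rise in this assay is therefore expected, close to the edge of the scatter. The expected step is a 1.5-fold higher number from compound 1 to compound 3 (0.18 log units; within the scatter) towards a weaker inhibitor. For compound 3 the estimate is 1800 nM as the central value, with 600 nM to 5000 nM as the expected range of the reading.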

Compound 3, half-maximal inhibitory concentration: 4200 nM
Estimate against measurement, compound 3: 2.3-fold (0.37 log units) below, and the stated range covers the measured number.
By their numbers in this assay, from the lowest: compound 1; then compounds 2 and 3 (each within the scatter of the next).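

In this assay, among these compounds, ethyl in place of hydrogen on an amine nitrogen in a ring gives a 3.5-fold higher number from compound 1 to compound 3 (0.54 log units; beyond the scatter), the first step that isolates a single change. It shows that this position is not indifferent to substitution: with the rest of compound 1 held fixed, the hydrogen-bearing compound has the lower number, and the ethyl-bearing compound 3 has a higher number by more than the usual scatter of the assay. Nothing measured here explains why the number rises with this change.

With only hydrogen and ethyl compared directly at this nitrogen, the compounds shown leave open whether a methyl group, a longer chain such as butyl, or a benzyl group would stay close to compound 1 or compound 3. Also open, from the compounds shown here alone, is whether the same ethyl step would hold on a core with different groups elsewhere, as compound 2 differs from both compound 1 and compound 3 in more than one place and cannot settle that question.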